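Bromo to iodo on the aromatic carbon: working notes

The compounds below may be only part of what the source reports. "The series", "measured", "known", "first", "only" and "open" are said of these compounds alone.

In a functional assay on Hs-578T cells (Homo sapiens) for inhibition, read by sulforhodamine B assay, with a stated time of 48 h (a higher number here means a weaker inhibitor of growth, a lower number a stronger inhibitor of growth), compound 1 `Cc1ccc(NC(=O)/C=C/c2ccccc2)c(C(N)=O)c1` gives 1940 nM while compound 2 `NC(=O)c1cc(Br)ccc1NC(=O)/C=C/c1ccccc1` gives 624 nM and so holds the lower of the two numbers, with a gap beyond the scatter. Compound 2 is therefore the stronger inhibitor of growth of the pair.

The next structure is compound 3 `NC(=O)c1cc(I)ccc1NC(=O)/C=C/c1ccccc1` with iodo in place of bromo on an aromatic carbon, meta to a carbamoyl group and para to a large group. The difference is iodo in place of bromo on an aromatic carbon and the rest of the structure stays unchanged.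

The step of a 3.1-fold lower number from compound 1 to compound 2 (0.49 log units; beyond the scatter) on replacing methyl with bromo at the same carbon is the only measured one that bears on this change, and it is modest. Within the data shown here, no iodo compound has been measured, and a single step sets no trend. A step in this assay no larger than that one is expected, leaning towards a lower number and possibly within the scatter.

Compound 3 is estimated at 520 nM with an expected range of 230 nM to 1150 nM in this series. That estimate means an expected 1.2-fold lower number from compound 2 to compound 3 (0.08 log units; within the scatter) and no more than that.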

Compound 3, concentration for 50% growth inhibition: 375 nM
For compound 3 the middle estimate is 1.4-fold (0.14 log units) above the measured one; the measured number falls inside the stated range.
By their numbers in this assay, from the lowest: compounds 3 and 2 (each within the scatter of the next); then compound 1.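

In this assay, iodo in place of bromo on this aromatic carbon, meta to a carbamoyl group and para to a large group, gives a 1.7-fold lower number from compound 2 to compound 3 (0.22 log units; within the scatter) and so leaves compound 2 and compound 3 not separated from each other, which means that this position takes iodo as well as it takes bromo. Iodo in place of methyl at the same carbon gives a 5.2-fold lower number from compound 1 to compound 3 (0.71 log units; beyond the scatter) and so the separation from the methyl compound, until now seen for bromo alone, holds for a second halogen, and none of the three compounds goes against this. Nothing measured here bears on why both halogen compounds stand apart from the methyl compound.

The compounds shown leave open whether fluoro or chloro on this carbon would stay with bromo and iodo or fall nearer to methyl, so the halogen picture rests on two members only. They also leave open whether a group of a different kind at this carbon, such as an amine, a carboxylic acid, a methoxy group or a longer alkyl chain, would hold the number reached with bromo and iodo.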